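Methyl for methoxy in the iodo series

This account rests on a few compounds, and the source may have more. Where it says the series, first, only, none or still open, it means among the compounds named here.

In a functional assay on HeLa cells (Homo sapiens) for cytotoxicity, read by MTT assay, with stated times of 3 h and 24 h (a higher number here means a weaker inhibitor, a lower number a stronger inhibitor), compound 1 (`COc1ccc(C2=[N+]3C(=Nc4c(-c5ccccc5)c5c(n4[B-]3(F)F)-c3ccc(OC)cc3CC5)C(c3ccccc3)=C2Br)cc1`) gives 830 nM, compound 2 (`COc1ccc2c(c1)CCc1c(-c3ccccc3)c3n(c1-2)[B-](F)(F)[N+]1=C(c2ccc(C)cc2)C(Br)=C(c2ccccc2)C1=N3`) gives 1200 nM, and compound 3 (`COc1ccc(C2=[N+]3C(=Nc4c(-c5ccccc5)c5c(n4[B-]3(F)F)-c3ccc(OC)cc3CC5)C(c3ccccc3)=C2I)cc1`) gives 81 nM, the lowest of the three numbers. Compound 4 (`COc1ccc2c(c1)CCc1c(-c3ccccc3)c3n(c1-2)[B-](F)(F)[N+]1=C(c2ccc(C)cc2)C(I)=C(c2ccccc2)C1=N3`) has yet to be measured. It differs from compound 3 by methyl in place of methoxy on an aromatic carbon, para to a large group: methyl in place of methoxy on an aromatic carbon. The same exchange among the bromo compounds gave a step of a 1.4-fold higher number from compound 1 to compound 2 (0.16 log units; within the scatter). The large step of a 10-fold lower number from compound 1 to compound 3 (1.01 log units; beyond the scatter) came from iodo in place of bromo, which compound 4 retains. On this single precedent, no step beyond the scatter is expected in this assay. The expected step runs a 1.4-fold higher number from compound 3 to compound 4 (0.13 log units; within the scatter). Compound 4 is estimated at 110 nM, with an expected range of 45 nM to 270 nM.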

Compound 4, half-maximal inhibitory concentration: 110 nM
For compound 4 middle estimate and measured number coincide at the digits printed; measured number inside the range.
By their numbers in this assay, from the lowest: compounds 3 and 4 (each within the scatter of the next); then compounds 1 and 2 (each within the scatter of the next).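

In this assay, the exchange of 4-methoxyphenyl to 4-methylphenyl now gives a 1.4-fold higher number from compound 3 to compound 4 (0.13 log units; within the scatter), so the small step seen among the bromo compounds recurs with iodo in place: the same change on two cores in this assay, a 1.4-fold higher number (0.16 log units; within the scatter) from compound 1 to compound 2 and a 1.4-fold higher number (0.13 log units; within the scatter) from compound 3 to compound 4, 1.1-fold (0.03 log units) apart, within the scatter of two such steps

The change from bromo to iodo, first seen with methoxy, also recurs with methyl, giving an 11-fold lower number from compound 2 to compound 4 (1.04 log units; beyond the scatter), and across these four compounds the two changes combine without a gap beyond the scatter: the same change on two cores in this assay, a 10-fold lower number (1.01 log units; beyond the scatter) from compound 1 to compound 3 and an 11-fold lower number (1.04 log units; beyond the scatter) from compound 2 to compound 4, 1.1-fold (0.03 log units) apart, within the scatter of two such steps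

As far as these compounds go, only methoxy and methyl have been compared at this aromatic carbon, so what an amine or a carboxylic acid would do there remains open.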